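This account rests on a few compounds, and the source may have more. Where it says the series, first, only, none or still open, it means among the compounds named here.

Three compounds share a long unsaturated chain ending in a carbonyl that carries a small aromatic ring. Compound 1 `CCCCCCCC/C=C\CCCCCCC(=O)c1ncc(-c2ccco2)o1` gives 54 nM in an assay on isolated protein for inhibition of Fatty-acid amide hydrolase 1 (Homo sapiens); on this read-out higher numbers stand for weaker inhibition and lower numbers for stronger inhibition. Compound 2 `CCCCCCCC/C=C\CCCCCCC(=O)c1nnn(C)n1` gives 65 nM in this assay. Compound 3 `CCCCCCCC/C=C\CCCCCCC(=O)c1nc2ncccc2o1` gives 2.3 nM in this assay, the lowest of the three numbers and the strongest inhibitor here, since its steps to compound 1 and to compound 2 both lie beyond the scatter.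

Compound 4 `CCCCCCCC/C=C\CCCCCCC(=O)c1ncco1` has not yet been measured. It differs from compound 3 in one place: a group of 5 heavy atoms (3 carbon, 1 nitrogen, 1 oxygen; one five-membered aromatic ring with 2 hetero atoms) in place of a group of 9 heavy atoms (6 carbon, 2 nitrogen, 1 oxygen; one five-membered aromatic ring with 2 hetero atoms, one six-membered aromatic ring with 1 hetero atom), on a carbonyl carbon. Among the measured compounds shown here, the one measured step on this carbonyl carbon, a 28-fold lower number from compound 2 to compound 3 (1.45 log units; beyond the scatter), shows that the fused two-ring group in compound 3 sits far ahead of a small single ring. Compound 1, which also carries a single five-membered ring at this position, though with a further ring attached, gives a number close to that of compound 2. Compound 4 is therefore expected to lose ground, with a step of a 35-fold higher number from compound 3 to compound 4 (1.54 log units; beyond the scatter) anticipated. The estimate for compound 4 in this assay is 80 nM, expected to fall between 20 nM and 300 nM.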

Compound 4, inhibition constant: 17 nM
Beside the measured number, compound 4's estimate is 4.7-fold (0.67 log units) above it; measured number below the stated range.
By their numbers in this assay, from the lowest: compound 3; then compound 4; then compounds 1 and 2 (each within the scatter of the next).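

Among the compounds shown here, the small ring alone already goes further than the earlier compounds suggested: on the carbonyl carbon, 1,3-oxazol-2-yl in place of 2-methyl-2H-tetrazol-5-yl gives a better result in this assay (a 3.8-fold lower number from compound 2 to compound 4 (0.58 log units; beyond the scatter)). Hydrogen in place of furan-2-yl on the aromatic carbon also improves the number (a 3.2-fold lower number from compound 1 to compound 4 (0.50 log units; beyond the scatter)), so the added furan ring brings no gain here. The two-ring group still keeps a real lead over the single oxazole ring (a 7.4-fold higher number from compound 3 to compound 4 (0.87 log units; beyond the scatter)), so the second ring of compound 3 adds to what the oxazole ring achieves alone.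

On these data alone, it remains open how a methyl group or a carboxylic acid in place of furan-2-yl on that aromatic carbon would fare. No measurement here explains why these groups rank as they do.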